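Flipping One Ring Stereocentre: Expectations for Compound 4

A few compounds are considered here, and "the series" means these few. Any claim that something is new, unique, unknown or untested is made for them only; others in the source may bear on it.

Of the compounds shown here, three have been measured in a functional assay on MCF7 cells (Homo sapiens) for inhibition; on this read-out lower numbers stand for stronger inhibition of growth and higher numbers for weaker inhibition of growth. Compound 1 `C=CCOC(=O)c1ccsc1NC(=O)[C@@H]1CCCN1` gives 96.6 ug/mL, compound 2 `COC(=O)c1sccc1NC(=O)[C@@H]1CCCN1` gives 163 ug/mL, and compound 3 `COC(=O)c1ccsc1NC(=O)[C@H]1CCCN1` gives 179 ug/mL. Compound 3 stands at the highest of the three numbers, though its gaps to compound 2 and to compound 1 both fall within the usual scatter, so no order among them can be claimed. Compound 4 `COC(=O)c1ccsc1NC(=O)[C@@H]1CCCN1` has not yet been measured. It differs from compound 3 as follows: the two compounds have the same atoms and bonds and differ only in configuration as drawn: 1 of 1 stereo elements differ; a stereocentre at a saturated ring carbon is drawn R in compound 3 and S in compound 4. Going by the values given here, no step between measured pairs is available to guide the size of this change, so the expected step of a 1.4-fold lower number from compound 3 to compound 4 (0.14 log units; within the scatter) in this assay is small, likely none beyond the scatter. Compound 4 is estimated at 130 ug/mL, within 60 ug/mL to 280 ug/mL.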

Compound 4, concentration for 50% growth inhibition: > 250 ug/mL
Compound 4 was reported as a limit; the forecaster's own chance of this, stated with the estimate: 10%; middle value at least 1.9-fold (0.28 log units) from the limit.
By their numbers in this assay, from the lowest: compounds 1, 2 and 3 (each within the scatter of the next). At a limit, above all of these: compound 4.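

In this assay compound 4 gives > 250 ug/mL, a limit of the assay and not a number. Flipping the ring stereocentre gives an at least 1.3-fold higher number from compound 3 to compound 4 (0.14 log units; that floor lies within the scatter), so this change may matter, but its true size cannot be read. Hydrogen in place of vinyl on a saturated chain carbon bound to an oxygen next to a carbonyl group gives an at least 2.5-fold higher number from compound 1 to compound 4 (0.41 log units; beyond the scatter), the first step here that clears the scatter.

Still open, from the compounds shown here alone, is how a carboxylic acid or an ethyl ester would read in place of the methyl ester. Also open, going by these compounds, is whether the allyl ester would respond to the same stereocentre flip.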